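The compounds below may be only part of what the source reports. "The series", "measured", "known", "first", "only" and "open" are said of these compounds alone.

Measured so far in a functional assay on HL-60 cells (Homo sapiens) for antiproliferative activity, read by MTT assay (on this read-out higher numbers stand for weaker inhibition and lower numbers for stronger inhibition), as follows:
- compound 1 `O[C@@H]1[C@@H](OCc2ccccc2)[C@H](OCc2ccccc2)[C@@H](COCc2ccccc2)O[C@H]1Cc1ccccc1` gives 8700 nM as the read-out
- compound 2 `CC[C@@H]1O[C@H](COCc2ccccc2)[C@@H](OCc2ccccc2)[C@H](OCc2ccccc2)[C@H]1O` gives 8200 nM as the read-out

Among the measured compounds shown here, compound 2 stands level with compound 1, the only other number available. For the measured compounds named here, their single step, methyl in place of phenyl, is small (a 1.1-fold lower number from compound 1 to compound 2 (0.03 log units; within the scatter)). Compound 3 `OCCC[C@@H]1O[C@H](COCc2ccccc2)[C@@H](OCc2ccccc2)[C@H](OCc2ccccc2)[C@H]1O` carries hydroxymethyl in place of hydrogen on a saturated chain carbon, two bonds along the chain from a saturated ring carbon. Going by the values given here, that one step is the only evidence bearing on this chain, and no measured step introduces hydroxymethyl, so the guidance is thin and the range is kept wide. With compound 2 at 8200 nM as the anchor, no shift beyond the scatter is expected in this assay for now. The estimated change is small (a 1.1-fold lower number from compound 2 to compound 3 (0.04 log units; within the scatter)). For compound 3 the expected value is 7500 nM (estimated range 2500 nM to 20000 nM).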

Compound 3, half-maximal inhibitory concentration: 19300 nM
Compound 3: the middle estimate sits 2.6-fold (0.41 log units) below what was measured; the range from low to high includes it.
By their numbers in this assay, from the lowest: compounds 2 and 1 (each within the scatter of the next); then compound 3.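

Among the compounds shown here, the step of a 2.4-fold higher number from compound 2 to compound 3 (0.37 log units; beyond the scatter) in this assay is the first to pass the scatter, so this chain position does respond to some changes, with weaker inhibition after hydroxymethyl replaces hydrogen on a saturated chain carbon, two bonds along the chain from a saturated ring carbon. The step of a 2.2-fold higher number from compound 1 to compound 3 (0.35 log units; beyond the scatter) points the same way, whereas the earlier exchange of phenyl for methyl left the numbers within the scatter. No available data explain this shift.

The compounds shown leave open whether the added chain length or the terminal hydroxyl goes with the weaker inhibition, a plain propyl chain being the group that would separate the two. Also open, on these data alone, is how a terminal amine or carboxylic acid on the same chain would read out.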